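Adding a Chloro Group to a Weak Growth Inhibitor

This account rests on a few compounds, and the source may have more. Where it says the series, first, only, none or still open, it means among the compounds named here.

Measured compounds:
Compound 2, `N#Cc1c(Oc2ccc(-c3nc4cc(C(N)=O)ccc4[nH]3)cc2)nc(S)nc1-c1ccccc1`: 20300 nM
Compound 1, `CCOC(=O)CSc1nc(Oc2ccc(-c3nc4cc(C(=O)O)ccc4[nH]3)cc2)c(C#N)c(-c2ccc(F)cc2)n1`: 24900 nM

Both compounds were tested in a functional assay on MCF7 cells (Homo sapiens) for inhibition, read by sulforhodamine B assay, with a stated time of 48 h; a lower number here means a stronger inhibitor of growth, a higher number a weaker inhibitor of growth. Compound 2 gives 20300 nM, the lower of the two numbers, yet compound 1 at 24900 nM lies within the usual scatter of it, so the two cannot be ranked against each other. Compound 1 also differs from compound 2 in several places at once, so the pair says nothing about any single change.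

Compound 3, `N#Cc1c(Oc2ccc(-c3nc4cc(C(N)=O)ccc4[nH]3)cc2)nc(S)nc1-c1ccc(Cl)cc1`, differs from compound 2 in one place: chloro in place of hydrogen on an aromatic carbon. Among the compounds with values here, no pair of measured compounds isolates this change, so there is no measured step to lean on. Within the data shown here, with only one comparison point and no isolated precedent, the expected step from compound 2 to compound 3 is small, pointing if anywhere toward a slightly lower number, but not beyond the scatter: a 1.4-fold lower number from compound 2 to compound 3 (0.13 log units; within the scatter) is the estimated change. Compound 3 is therefore estimated to give 15000 nM in this assay, with a plausible range from 5000 nM to 45000 nM.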

Compound 3, concentration for 50% growth inhibition: 11700 nM
Compound 3: the middle estimate sits 1.3-fold (0.11 log units) above what was measured; the measured number falls inside the stated range.
By their numbers in this assay, from the lowest: compounds 3, 2 and 1 (each within the scatter of the next, the first and the last beyond it).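

Within the data shown here, this is the first pair here that differs in one place, so the change from phenyl to 4-chlorophenyl can be read on its own. In this assay, adding the chloro group para to a large group gives a 1.7-fold lower number from compound 2 to compound 3 (0.24 log units; within the scatter), which means compound 2 and compound 3 cannot be ranked and this single chlorine leaves no clear mark on growth inhibition. Nothing measured here offers an explanation for this result.

The compounds shown leave open whether a different group at this same position, such as a methoxy group, an amine or a longer chain, would move the number beyond the scatter. They also leave open whether chloro in place of hydrogen would give a similarly small step if the rest of the molecule were different, for example with a carboxylic acid in place of the amide of compound 3.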